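The source may report more compounds than this note shows. Statements on the series, on what has been measured and on what is new or still open speak of the compounds shown alone.

Of the compounds shown here, three sharing one core have been measured so far in a functional assay on HEL cells (Homo sapiens); a lower number here means that less compound is tolerated, a higher number that more compound is tolerated. Compound 1 (`Cc1cn([C@@H]2O[C@H](CO[Si](C)(C)C(C)(C)C)[C@@]3(OS(=O)(=O)C=C3NCC(=O)O)[C@H]2O[Si](C)(C)C(C)(C)C)c(=O)n(C)c1=O`) gives 136000 nM and compound 3 (`Cc1cn([C@@H]2O[C@H](CO[Si](C)(C)C(C)(C)C)[C@@]3(OS(=O)(=O)C=C3NCC(=O)C(=O)O)[C@H]2O[Si](C)(C)C(C)(C)C)c(=O)n(C)c1=O`) gives 146000 nM so these two sit together at the high end of the numbers (a 1.1-fold higher number from compound 1 to compound 3 (0.03 log units; within the scatter)). Compound 2 (`C=C(C)C(=O)NC(=O)NC1=CS(=O)(=O)O[C@@]12[C@@H](CO[Si](C)(C)C(C)(C)C)O[C@@H](n1cc(C)c(=O)n(C)c1=O)[C@@H]2O[Si](C)(C)C(C)(C)C`) lies far lower at 1200 nM on the same scale.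

Compound 4 (`CCNC(=O)NC1=CS(=O)(=O)O[C@@]12[C@@H](CO[Si](C)(C)C(C)(C)C)O[C@@H](n1cc(C)c(=O)n(C)c1=O)[C@@H]2O[Si](C)(C)C(C)(C)C`) differs from compound 3 in one place, with ethylcarbamoyl in place of (carboxycarbonyl)methyl on an amine nitrogen. The nearest guide is compound 2, which also has a carbamoyl group on that nitrogen. Both steps linking compound 2 with the carboxy-bearing compounds are large (a 110-fold lower number from compound 1 to compound 2 (2.05 log units; beyond the scatter) and a 120-fold higher number from compound 2 to compound 3 (2.09 log units; beyond the scatter)). Going by the values given here, no measured compound shows how an ethyl end compares with the end of the group in compound 2, so some uncertainty remains.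

In this assay a large downward step is expected, estimated as a 37-fold lower number from compound 3 to compound 4 (1.56 log units; beyond the scatter) in size. The estimate for compound 4 is 4000 nM (expected range 1000 nM to 25000 nM).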

Compound 4, half-maximal cytotoxic concentration: 10000 nM
The estimate for compound 4 lay 2.5-fold (0.40 log units) below the measured number; measured number inside the range.
By their numbers in this assay, from the lowest: compound 2; then compound 4; then compounds 1 and 3 (each within the scatter of the next).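

In this assay, the low number of compound 2 does not depend on its (1-methylethenyl)carbonyl end alone: a plain ethylcarbamoyl group on the amine nitrogen also gives a much lower number than either carboxy-bearing compound, with a 14-fold lower number from compound 1 to compound 4 (1.13 log units; beyond the scatter) and a 15-fold lower number from compound 3 to compound 4 (1.16 log units; beyond the scatter) as the two steps. The end of the group still counts, since ethyl in place of (1-methylethenyl)carbonyl gives an 8.3-fold higher number from compound 2 to compound 4 (0.92 log units; beyond the scatter) and so recovers part of the drop. No measurement here explains either effect.

Compounds 2 and 4 both gain a carbamoyl group and lose the carboxy group, so these compounds cannot show which of the two changes drives the drop. A carbamoyl group ending in a carboxylic acid would separate them, and a longer chain in place of ethyl would show how far the trend from the (1-methylethenyl)carbonyl end continues.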